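A Second Benzyl Change in a Weakly Cytotoxic Pair

The source may hold more compounds than are shown below. What is called first, only, known or untested is meant among the compounds shown, and "the series" means these compounds.

Compound 1 `O=c1ccoc2cc(OCc3cn(Cc4ccc(Cl)cc4)nn3)ccc12` and compound 2 `O=c1ccoc2cc(OCc3cn(Cc4cccc(Br)c4)nn3)ccc12` share one core and differ only in the group on a saturated chain carbon bound to an aromatic nitrogen, 4-chlorophenyl against 3-bromophenyl. In a functional assay on HeLa cells (Homo sapiens) for cytotoxicity, read by MTT assay, with a stated time of 48 h (a lower number here means a stronger inhibitor, a higher number a weaker inhibitor), compound 1 gives 37600 nM. For compound 2 this assay reports no number but only a limit, > 100000 nM. The step of an at least 2.6-fold higher number from compound 1 to compound 2 (0.42 log units; beyond the scatter) is therefore known only as a bound, because compound 2 sits at the limit of > 100000 nM in this assay, at which 1 of the 2 values shown sits. Compound 2 thus stands at the weak end of what the two measurements show, without a value of its own.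

Compound 3 `Cc1ccccc1Cn1cc(COc2ccc3c(=O)ccoc3c2)nn1` is reached from compound 2 by one change: 2-methylphenyl in place of 3-bromophenyl on a saturated chain carbon bound to an aromatic nitrogen. Going by the values given here, the only measured step, from compound 1 to compound 2, altered the same group and moved the number upward by at least a modest amount, yet it cannot fix a direction here, since it starts from a measured value and ends at a bound. Compound 3 is expected to sit close to compound 2, with a step of an at least 1.4-fold lower number from compound 2 to compound 3 (0.15 log units; that floor lies within the scatter) that is not estimated to lie beyond the scatter. Compound 3 is accordingly expected to give 70000 nM in this assay, within 25000 nM to 200000 nM.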

Compound 3, half-maximal inhibitory concentration: 15300 nM
For compound 3 the middle estimate is 4.6-fold (0.66 log units) above the measured one; the whole stated range lies above it.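

Going by these compounds alone, compound 3 shows that this place, on a saturated chain carbon bound to an aromatic nitrogen, can also move the number downward, whereas the one earlier step had moved it only upward. In this assay the change from 3-bromophenyl to 2-methylphenyl brings an at least 6.5-fold lower number from compound 2 to compound 3 (0.81 log units; beyond the scatter), a step known only as a bound: the limit of > 100000 nM in this assay, at which 1 of the 3 values shown sits. The comparison with a measured value at both ends is a 2.5-fold lower number from compound 1 to compound 3 (0.39 log units; beyond the scatter), which makes compound 3 the strongest of the three compounds shown, although all three remain weakly cytotoxic.

The compounds shown leave open whether the lower number belongs to the methyl group itself or to the 2-methylphenyl group as a whole, as the three aryl groups differ in both the kind of substituent and where it sits. They also leave open how this place would read with an amine, a carboxylic acid or a longer chain in place of the aryl group, and whether any group here would give a number far lower than that of compound 3.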